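Swapping a Pentyl Chain for an Isobutylcarbonyl Ester

The compounds below may be only part of what the source reports. "The series", "measured", "known", "first", "only" and "open" are said of these compounds alone.

Measured compounds in a functional assay on A549 cells (Homo sapiens) for cytotoxicity, with a stated time of 48 h; on this read-out higher numbers stand for weaker inhibition and lower numbers for stronger inhibition:
compound 1, `C[S+]([O-])/C=C/c1cc(=O)c2cc(C#N)ccc2o1`: > 10000 nM, which is a limit of the assay rather than a number.
compound 2, `CC(C)C(=O)Oc1ccc2oc(/C=C/[S+](C)[O-])cc(=O)c2c1`: 2400 nM.
compound 3, `CCCCCOc1ccc2oc(/C=C/[S+](C)[O-])cc(=O)c2c1`: 1600 nM.

Compound 3 gives the lowest of the two actual numbers, but its nearest neighbour, compound 2, differs from it only by a 1.5-fold lower number from compound 2 to compound 3 (0.18 log units; within the scatter), a gap within the scatter, so the two cannot be ranked against each other. Compound 1 sits at the limit (the limit of > 10000 nM in this assay, at which 1 of the 3 values shown sits). From there the steps of an at least 4.1-fold lower number from compound 1 to compound 2 (0.61 log units; beyond the scatter) and an at least 6.2-fold lower number from compound 1 to compound 3 (0.79 log units; beyond the scatter) are both beyond the scatter, so compound 2 and compound 3 stand clearly apart from compound 1.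

Compound 4, `CC(C)CC(=O)Oc1ccc2oc(/C=C/[S+](C)[O-])cc(=O)c2c1`, has not yet been measured. Compared with compound 3 it carries isobutylcarbonyl in place of pentyl on an oxygen on an aromatic ring. Going by the values given here, the one measured step that bears on this change is a 1.5-fold lower number from compound 2 to compound 3 (0.18 log units; within the scatter), where an isopropylcarbonyl group and a pentyl group on the same oxygen gave numbers within the scatter. Compound 4 carries an isobutylcarbonyl group, a close relative of the isopropylcarbonyl group of compound 2, so the step of a 1.3-fold higher number from compound 3 to compound 4 (0.10 log units; within the scatter) is expected to stay within the scatter, perhaps drifting slightly toward a higher number. Compound 4 is therefore estimated at 2000 nM, with a range from 800 nM to 5000 nM.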

Compound 4, half-maximal inhibitory concentration: 2300 nM
Estimate against measurement, compound 4: 1.2-fold (0.06 log units) below; the measured number falls inside the stated range.
By their numbers in this assay, from the lowest: compounds 3, 4 and 2 (each within the scatter of the next). At a limit, above all of these: compound 1.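

In this assay, an ester and a plain ether chain on this oxygen give values that cannot be told apart (a 1.4-fold higher number from compound 3 to compound 4 (0.16 log units; within the scatter)), even though isobutylcarbonyl brings a carbonyl and a hydrogen-bond acceptor that pentyl lacks. The branched acyl chain also matches the shorter one, with isobutyl and isopropyl on the carbonyl carbon lying within the scatter (a 1.0-fold lower number from compound 2 to compound 4 (0.02 log units; within the scatter)), so compounds 2, 3 and 4 now form a group of three with no order among them and none going against that reading. Compound 1, with cyano on the aromatic carbon in place of the oxygen-linked group, gives only a limit and not a number, so the step (an at least 4.3-fold lower number from compound 1 to compound 4 (0.63 log units; beyond the scatter)) is a bound rather than a measured gap: (the limit of > 10000 nM in this assay, at which 1 of the 4 values shown sits).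

As far as these compounds go, what an amine or a carboxylic acid at the end of the chain on this oxygen would do, or a much longer chain, remains open. It is also open whether the separation from compound 1 depends on the oxygen link itself, since a simple hydroxyl or methoxy group on that aromatic carbon is not among the compounds shown.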